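The compounds below may be only part of what the source reports. "The series", "measured", "known", "first", "only" and "open" are said of these compounds alone.

Compound 1 (`COc1ncnc2c1c(-c1ccccc1)cn2[C@@H]1O[C@H](CO)[C@@H](O)[C@H]1O`), compound 2 (`Nc1nc(N)c2c(-c3ccco3)cn([C@@H]3O[C@H](CO)[C@@H](O)[C@H]3O)c2n1`) and compound 3 (`COc1nc(N)nc2c1c(-c1ccco1)cn2[C@@H]1O[C@H](CO)[C@@H](O)[C@H]1O`) were all tested in a functional assay on K562 cells (Homo sapiens), read by MTT assay, with a stated time of 72 h; on this read-out lower numbers stand for stronger inhibition and higher numbers for weaker inhibition. In this assay compound 1 gives > 20000 nM as its result, which is a limit and not a number. Compound 2 gives > 20000 nM as its result, again a limit. Compound 3 gives > 20000 nM as its result, also a limit. Compound 3 therefore shares its place with the other two, and the whole set reads as the limit of > 20000 nM in this assay, at which 3 of the 3 values shown sit, with no number to rank them.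

Compound 4 (`COc1nc(N)nc2c1c(-c1ccoc1)cn2[C@@H]1O[C@H](CO)[C@@H](O)[C@H]1O`) has the same atoms as compound 3, joined differently: furan-3-yl in place of furan-2-yl on an aromatic carbon in short, furan-3-yl in place of furan-2-yl on an aromatic carbon. Within the data shown here, the only measured step is a step that the two limits leave unreadable from compound 2 to compound 3 and it concerns methoxy in place of amino on an aromatic carbon, so it offers no size to carry over. With nothing readable to go on, no step beyond the scatter is expected in this assay and no direction is favoured. The expected change is a number no higher from compound 3 to compound 4 (the limit leaves the size open) in this estimate. For compound 4 the estimated value is 20000 nM with an expected range from 8000 nM to 30000 nM and another limit is the likeliest report.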

Compound 4, half-maximal inhibitory concentration: > 20000 nM
Compound 4 ended at the assay's limit (the forecaster's own chance of this, stated with the estimate: 85%); the middle value sits exactly at the limit.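

Among these compounds, compound 3 and compound 4 both end at a limit, so putting furan-3-yl in place of furan-2-yl gives no step that can be read in this assay. All the compounds shown share one result: the limit of > 20000 nM in this assay, at which 4 of the 4 values shown sit. They leave open which change, if any, would give a value that could be ranked as a number.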